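From Methoxy to Tert-Butoxy: Estimating Compound 3

The source may hold more compounds than are shown below. What is called first, only, known or untested is meant among the compounds shown, and "the series" means these compounds.

Going by the values given here, compound 1 `COc1cc(-c2cnn3cc(OC)c(-c4cnn(C)c4)nc23)ccn1` gives 530 nM in an assay on isolated protein for inhibition of activin receptor type-2A (Homo sapiens), read by 33P incorporation, with a stated time of 20 min, in the presence of a further agent that is not named here (a higher number here means a weaker inhibitor, a lower number a stronger inhibitor), the lower of the two numbers known. Compound 2 `COc1cc(-c2cnn3cc(OC)c(C4CCOC4)nc23)ccn1` gives 1900 nM in this assay, and a 3.6-fold higher number from compound 1 to compound 2 (0.55 log units; beyond the scatter). Compound 3 `COc1cn2ncc(-c3ccnc(OC(C)(C)C)c3)c2nc1-c1cnn(C)c1` differs from compound 1 by tert-butyl in place of methyl on an oxygen on an aromatic ring. Among the compounds with values here, the one measured step, from compound 1 to compound 2, concerns a different place on the shared core, so no measured step bears on this change, and only a modest movement in either direction is expected. Compound 3 is expected to give an estimated 900 nM, within 250 nM to 3500 nM. That expectation amounts to a 1.7-fold higher number from compound 1 to compound 3 (0.23 log units; within the scatter).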

Compound 3, half-maximal inhibitory concentration: 800 nM
For compound 3 the middle estimate is 1.1-fold (0.05 log units) above the measured one; the measured number falls inside the stated range.
By their numbers in this assay, from the lowest: compounds 1 and 3 (each within the scatter of the next); then compound 2.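

In this assay, replacing methyl with tert-butyl on this oxygen, 4 heavy atoms in place of 1, leaves the number within the scatter (a 1.5-fold higher number from compound 1 to compound 3 (0.18 log units; within the scatter)). This place on an aromatic ring therefore accepts the change from methoxy to tert-butoxy without a readable loss, whereas the change elsewhere on the shared core moved the number beyond the scatter (a 3.6-fold higher number from compound 1 to compound 2 (0.55 log units; beyond the scatter)). No measurement here explains this result. From the compounds shown here alone, whether a longer chain, or an oxygen carrying an amine or a carboxylic acid, would fare the same remains open.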